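The source may hold more compounds than are shown below. What is called first, only, known or untested is meant among the compounds shown, and "the series" means these compounds.

Three compounds of this set have been run in an assay on isolated protein for inhibition of Aromatase (Homo sapiens), read by fluorescence, using NADPH, with a stated time of 30 min, tested at 50 uM; on this read-out lower numbers stand for less inhibition and higher numbers for more inhibition at the one concentration tested (going by the name of the read-out). Compound 1 `COc1cc(OC)cc(-c2cc3ccccc3[nH]2)c1` gives 9.18%. Compound 2 `C(=N/OCc1ccccc1)\c1c(-c2ccccc2)[nH]c2ccccc12` gives 23.3%, and compound 3 `CN(C)c1ccc(-c2cc3ccccc3[nH]2)cc1` gives 0%. On these three numbers compound 1 stands second highest: its nearest neighbour is compound 3, whose number lies lower but within the scatter, and its furthest is compound 2, whose number lies higher and beyond the scatter. Going by the values given here, no pair of measured compounds differing in one place is available, so no measured step guides the next move.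

Compound 4 `COc1cccc(-c2cc3ccccc3[nH]2)c1` is not yet measured in this assay. From compound 1 it differs by hydrogen in place of methoxy on an aromatic carbon. Because compound 1 at 9.18% and compound 3 at 0% sit within the scatter of each other, only a small step is expected for compound 4 in this assay. The expected step is a number 2.2 percentage points lower from compound 1 to compound 4 (within the scatter), downward if anything, and not beyond the scatter. Compound 4 is therefore estimated at 7%, with a range from 0% to 20%.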

Compound 4, a percentage reported as inhibition, at one concentration (the size of the read-out at that concentration, not a potency): 48.4%
Compound 4: the middle estimate sits 41.4 percentage points below what was measured; the measured number lies above the stated range.
By their numbers in this assay, from the lowest: compounds 3 and 1 (each within the scatter of the next); then compound 2; then compound 4.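

In this assay, going by these compounds alone, hydrogen in place of methoxy on an aromatic carbon gives a number 39.2 percentage points higher from compound 1 to compound 4 (beyond the scatter), the first measured step, and it is large. This place, meta to a group of 9 heavy atoms and meta to a methoxy group, is therefore not indifferent to substitution: with the second methoxy present, compound 1 gives 9.18%, and without it, compound 4 gives 48.4%. Nothing at hand accounts for the size of this step.

The compounds shown leave open whether any group on this carbon lowers the number or whether methoxy alone does so, and a hydroxyl group or a fluorine atom there would separate the two. What the remaining methoxy contributes also stays open, as no pair shown changes that group.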